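A few compounds are considered here, and "the series" means these few. Any claim that something is new, unique, unknown or untested is made for them only; others in the source may bear on it.

Compound 1, `CC(C)C(Nc1nccs1)c1ccc(-c2ccc3cccc(F)c3c2)[nH]c1=O`: 9.4 nM
Compound 2, `CC(C)C(/C=C1/CCNC1=O)c1ccc(-c2ccc3cccc(F)c3c2)[nH]c1=O`: 5.3 nM
Compound 3, `CC(C)C(CC(N)=O)c1ccc(-c2ccc3cccc(F)c3c2)[nH]c1=O`: 5 nM

In an assay on CHO cells for displacement of a labelled ligand from prostaglandin E2 receptor EP3 subtype (Homo sapiens), read by radioligand binding (a higher number here means a weaker inhibitor, a lower number a stronger inhibitor), compound 3 gives the lowest of the three numbers, though both neighbours sit close: a 1.9-fold lower number from compound 1 to compound 3 (0.27 log units; within the scatter) and a 1.1-fold lower number from compound 2 to compound 3 (0.03 log units; within the scatter) remain within the scatter. Compound 4, `CC(C)NC(=O)CC(c1ccc(-c2ccc3cccc(F)c3c2)[nH]c1=O)C(C)C`, differs from compound 3 in one place: isopropyl in place of hydrogen on an amide-type nitrogen. Within the data shown here, no measured step touches an amide-type nitrogen in this way; each of them swaps the whole side group, and a 1.8-fold lower number from compound 1 to compound 2 (0.25 log units; within the scatter), a 1.9-fold lower number from compound 1 to compound 3 (0.27 log units; within the scatter) and a 1.1-fold lower number from compound 2 to compound 3 (0.03 log units; within the scatter) all stay within the scatter. Three quite different side groups thus leave the numbers close together, which gives no ground to expect a step beyond the scatter in this assay in either direction. Compound 4 is accordingly expected to give about 7 nM (range 2.5 nM to 20 nM), a step of a 1.4-fold higher number from compound 3 to compound 4 (0.15 log units; within the scatter).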

Compound 4, inhibition constant in the prostaglandin E2 receptor EP3 subtype assay: 5.8 nM
The estimate for compound 4 lay 1.2-fold (0.08 log units) above the measured number; low and high end bracket the measured number.
By their numbers in the prostaglandin E2 receptor EP3 subtype assay, from the lowest: compounds 3, 2, 4 and 1 (each within the scatter of the next).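

In the prostaglandin E2 receptor EP3 subtype assay the amide-type nitrogen carries isopropyl in place of hydrogen with no step beyond the scatter, a 1.2-fold higher number from compound 3 to compound 4 (0.06 log units; within the scatter), and the other comparisons stay inside it too: a 1.1-fold higher number from compound 2 to compound 4 (0.04 log units; within the scatter), and a 1.6-fold lower number from compound 1 to compound 4 (0.21 log units; within the scatter). This is the first change on that nitrogen rather than a swap of the whole side group, and in a physicochemical assay for solubility, in phosphate buffer, measured as kinetic solubility (a higher number here means a more soluble compound, a lower number a less soluble compound), compound 3 gives 5600 nM while compound 4 gives 18000 nM and the change does separate the two compounds: the measured solubility of compound 3, 5600 nM, and of compound 4, 18000 nM, a 3.2-fold higher number (0.51 log units; beyond the scatter)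

The compounds shown leave open whether a longer chain, a cyclohexyl ring or a hydroxyethyl group on this nitrogen would keep the number in the prostaglandin E2 receptor EP3 subtype assay in the same range. They also leave open whether any of these would move the number in the physicochemical assay as isopropyl does.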